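Branching the sulfonyl side chain: solubility working notes

The source may report more compounds than this note shows. Statements on the series, on what has been measured and on what is new or still open speak of the compounds shown alone.

Compound 1 `CCNC(=O)Nc1ccc(-c2nc(CS(C)(=O)=O)cc([C@]34CCOC[C@H]3C4)n2)cc1` gives 96 ug/mL in a physicochemical assay for solubility, in phosphate buffer, measured as kinetic solubility, with a stated time of 1 h, at pH 7.4; on this read-out lower numbers stand for lower solubility and higher numbers for higher solubility. Compound 3 `CCNC(=O)Nc1ccc(-c2nc(C(C)(C)S(C)(=O)=O)cc([C@]34CCOC[C@H]3C4)n2)cc1` differs from it by 1-methyl-1-(methylsulfonyl)ethyl in place of (methylsulfonyl)methyl on an aromatic carbon, and in this assay compound 3 gives 74 ug/mL; the step of a 1.3-fold lower number from compound 1 to compound 3 (0.11 log units; within the scatter) stays within the scatter. Compound 2 `CS(=O)(=O)Cc1cc([C@]23CCOC[C@H]2C3)nc(-c2cccc(O)c2)n1` rests on another core, and how the two cores differ is not broken down here; in this assay compound 2 gives 75 ug/mL, within the scatter of compound 1 and compound 3. Compound 4 `CC(C)(c1cc([C@]23CCOC[C@H]2C3)nc(-c2cccc(O)c2)n1)S(C)(=O)=O` differs from compound 2 by 1-methyl-1-(methylsulfonyl)ethyl in place of (methylsulfonyl)methyl on an aromatic carbon. This is the same kind of change as made from compound 1 to compound 3, though the surroundings differ: in compound 2 the place is meta to a 3-hydroxyphenyl group (7 heavy atoms), in compound 1 meta to a large group. For compound 4 the expected step is a 1.3-fold lower number from compound 2 to compound 4 (0.10 log units; within the scatter), resting on a 1.3-fold lower number from compound 1 to compound 3 (0.11 log units; within the scatter) and set beside it. Compound 4 is estimated at 60 ug/mL, with a range from 30 ug/mL to 120 ug/mL.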

Compound 4, solubility: 135 ug/mL
Estimate against measurement, compound 4: 2.3-fold (0.35 log units) below; measured number above the stated range.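

In this assay, a 1.8-fold higher number from compound 2 to compound 4 (0.26 log units; within the scatter) lies within the scatter, as does a 1.3-fold lower number from compound 1 to compound 3 (0.11 log units; within the scatter). Carrying 1-methyl-1-(methylsulfonyl)ethyl in place of (methylsulfonyl)methyl from one core to the other therefore gives no step beyond the scatter on either core, and the opposite directions of the two steps do not show that the outcome depends on the core. No supporting data bear on the difference in direction between these two pairs.

Going by these compounds, whether the same change stays within the scatter on any further core remains open. Also open, on these data alone, is what an amine, a carboxylic acid or a longer chain at this place would give in this assay.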